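Swapping one chloro for a methyl on a dichlorophenyl amide

This account rests on a few compounds, and the source may have more. Where it says the series, first, only, none or still open, it means among the compounds named here.

Measured so far in an assay on isolated protein (Mus musculus) for inhibition of IL15-IL15 receptor (Homo sapiens), read by resazurin assay, with stated times of 30 min and 2.5 days; a lower number here means a stronger inhibitor, a higher number a weaker inhibitor:
- compound 1 `Cn1c(Cc2nn(C)c(=O)c3ccccc23)nnc1SCCCCCCCCCCCCCCCC(=O)Nc1ccc(Cl)cc1Cl`: 7300 nM
- compound 2 `Cn1c(Cc2nn(C)c(=O)c3ccccc23)nnc1SCCCC(=O)Nc1ccc(Cl)cc1Cl`: 9800 nM
- compound 3 `Cn1c(Cc2nn(C)c(=O)c3ccccc23)nnc1SCCCCCCCC(=O)Nc1ccc(Cl)cc1Cl`: 1900 nM

All three compounds share the same core and the same (2,4-dichlorophenyl)carbamoyl end, differing only in the length of the chain between them. In this assay compound 3 gives 1900 nM, the lowest of the three numbers, and it therefore stands as the strongest inhibitor here: compound 1 gives 7300 nM and compound 2 gives 9800 nM, both gaps lying beyond the usual scatter.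

Compound 4 `Cc1ccc(NC(=O)CCCCCCCSc2nnc(Cc3nn(C)c(=O)c4ccccc34)n2C)c(Cl)c1` keeps the chain of compound 3 and changes only the aromatic end:

methyl in place of chloro on an aromatic carbon

Going by the values given here, no pair of measured compounds shows this kind of change, so there is no measured step to lean on. Because compound 3 gives 1900 nM and the change is a one-atom swap on the outer ring, the step from compound 3 to compound 4 is expected to be small, likely within the scatter. Compound 4 is thus estimated at 2500 nM, in a range from 800 nM to 8000 nM, with a 1.3-fold higher number from compound 3 to compound 4 (0.12 log units; within the scatter) expected.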

Compound 4, half-maximal inhibitory concentration: 2300 nM
Estimate against measurement, compound 4: 1.1-fold (0.04 log units) above, and the stated range covers the measured number.
By their numbers in this assay, from the lowest: compounds 3 and 4 (each within the scatter of the next); then compounds 1 and 2 (each within the scatter of the next).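

The earlier compounds shown here differed only in chain length, so they said nothing about the aromatic end. In this assay, going from 2,4-dichlorophenyl to 2-chloro-4-methylphenyl gives a 1.2-fold higher number from compound 3 to compound 4 (0.08 log units; within the scatter), which shows that at this ring carbon, para to a large group and meta to a chloro group, a methyl in place of the chloro leaves the number within the usual scatter on this chain. Nothing measured here offers a reason for this result.

On these data alone, what an amine or a carboxylic acid would do at this same carbon remains open, as does the effect of changing the remaining chloro group. As far as these compounds go, it is also open whether the same swap would give a similar result on the shorter chain of compound 2 or the longer chain of compound 1.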